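Benzyl to pyrimidin-2-yl at a cytotoxicity limit

The compounds below may be only part of what the source reports. "The series", "measured", "known", "first", "only" and "open" are said of these compounds alone.

Compound 1 `CN1C(=S)[C@@H](NC(=O)c2nc(Cc3ccccc3)n(C3CCOC3)n2)COc2ccccc21`: > 100000 nM (a limit)
Compound 2 `CN1C(=S)[C@@H](NC(=O)c2nc(Cc3ccccc3)n(Cc3ccccc3)n2)COc2ccccc21`: > 100000 nM (a limit)

Both compounds were tested in a toxicity assay on HT-29 cells (Homo sapiens) for cytotoxicity (a lower number here means that less compound is tolerated, a higher number that more compound is tolerated), and neither gave a number.

Compound 2 stands at > 100000 nM, which is a limit of the assay and not a number. Compound 3 `CN1C(=S)[C@@H](NC(=O)c2nc(Cc3ccccc3)n(-c3ncccn3)n2)COc2ccccc21` keeps the rest of compound 2 but carries pyrimidin-2-yl in place of benzyl on an aromatic nitrogen of a five-membered aromatic ring with 3 nitrogen: pyrimidin-2-yl in place of benzyl on an aromatic nitrogen.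

Among the measured compounds shown here, the one measured step that bears on this change sits on that same aromatic nitrogen. It is a step that the two limits leave unreadable from compound 1 to compound 2, and its size cannot be read. For the measured compounds named here, the data therefore offer no step of known size to carry over to compound 3, and no direction can be expected in this assay. Compound 3 is expected to stay close to the top of the range because of the limit of > 100000 nM in this assay, at which 2 of the 2 values shown sit.

The expected change is a number no higher from compound 2 to compound 3 (the limit leaves the size open).

For compound 3 the estimated value is 100000 nM, with an expected range from 40000 nM to 200000 nM.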

Compound 3, half-maximal cytotoxic concentration: > 100000 nM
Compound 3: only a limit was reported; the forecaster's own chance of this, stated with the estimate: 85%; the middle value lies on the limit itself.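

In this assay compound 3 gives > 100000 nM, a limit of the assay and not a number. Among the compounds shown here, no step among compound 1, compound 2 and compound 3 can be read from these results. The compounds shown leave open whether oxolan-3-yl, benzyl and pyrimidin-2-yl on the aromatic nitrogen differ at all in cytotoxicity, and at what concentration any of these compounds would reach its half-maximal cytotoxic effect.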